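Three limits and a fluorophenyl amide still to come

The source may hold more compounds than are shown below. What is called first, only, known or untested is meant among the compounds shown, and "the series" means these compounds.

Compound 3 `COc1ccc(-c2cnc(NC(=O)c3cccc(C#N)c3)n2C)cc1` carries a 3-cyanophenyl amide on the shared core. In a toxicity assay on THP-1 cells (Homo sapiens) for inhibition (on this read-out higher numbers stand for lower toxicity in this test and lower numbers for higher toxicity in this test), compound 3 gives > 100000 nM, which is a limit of the assay and not a number. Compound 1 `CCCC(=O)Nc1ncc(-c2ccc(OC)cc2)n1C` bears a propyl on the carbonyl carbon instead. In this assay compound 1 gives > 100000 nM, again a limit. The step that the two limits leave unreadable from compound 1 to compound 3 therefore cannot be sized. Compound 2 `Cn1c(-c2ccc(F)cc2)cnc1NC(=O)c1ccc(F)cc1` has a 4-fluorophenyl on the carbonyl carbon and a fluorine on its other aryl ring. In this assay compound 2 gives > 100000 nM, once more a limit. In sum, (the limit of > 100000 nM in this assay, at which 3 of the 3 values shown sit).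

Compound 4 `COc1ccc(-c2cnc(NC(=O)c3ccc(F)cc3)n2C)cc1` differs from compound 3 in one place: 4-fluorophenyl in place of 3-cyanophenyl on a carbonyl carbon. Going by the values given here, no measured step matches this change; the single step measured is unreadable, and compound 2, which shares the 4-fluorophenyl amide, sits at the same limit as every other compound here. The expected step that the limit leaves unreadable from compound 3 to compound 4 is therefore none beyond the scatter, and compound 4 is expected to remain at the limit of this assay. Compound 4 is estimated at 150000 nM, within a range from 60000 nM to 400000 nM, most likely reported as a limit again.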

Compound 4, half-maximal cytotoxic concentration: >= 50000 nM
Compound 4: no number, only a limit (the forecaster's own chance of this, stated with the estimate: 85%); the middle value is on the limit's open side.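

In this assay compound 4 gives >= 50000 nM, which is a limit of the assay and not a number. Going by these compounds alone, no step to compound 4 from compound 1, compound 2 or compound 3 can be read. The compounds shown leave open whether any change on the carbonyl carbon, or methoxy in place of fluoro on an aromatic carbon, alters the read-out in this assay at all.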